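Changing the Ester Tail of a Potent Dihydropyridine

The source may hold more compounds than are shown below. What is called first, only, known or untested is meant among the compounds shown, and "the series" means these compounds.

Measured so far:
- Compound 1, `CCOC(=O)C1=C(C)NC(COC)=C(C(=O)OC)C1c1ccccc1[N+](=O)[O-]`: 1760 nM
- Compound 2, `COC(=O)C1=C(C)NC(C)=C(C(=O)OCC(F)(F)F)C1c1cccc([N+](=O)[O-])c1`: 16 nM

In a functional assay on HEK293 cells for antagonist activity at Voltage-dependent L-type calcium channel subunit alpha-1C (Oryctolagus cuniculus), read by FLIPR (on this read-out lower numbers stand for stronger inhibition and higher numbers for weaker inhibition), compound 2 gives 16 nM, the lowest of the two numbers. Its nearest neighbour, compound 1, gives 1760 nM, a gap well beyond the scatter, so compound 2 is the stronger inhibitor of the pair. The two differ in several places at once, so no single change can be credited for that gap.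

Compound 3, `COC(=O)C1=C(C)NC(C)=C(C(=O)OCCc2ccc(Cl)cc2)C1c1cccc([N+](=O)[O-])c1`, has not yet been measured. It keeps everything of compound 2 except one part of the ester: 4-chlorobenzyl in place of trifluoromethyl on a saturated chain carbon bound to an oxygen next to a carbonyl group. A step of this kind on the ester side is expected to leave inhibition largely unchanged or shift it only modestly, and the direction is uncertain. The estimated step of a 1.3-fold higher number from compound 2 to compound 3 (0.10 log units; within the scatter) is expected to stay close to the scatter. Compound 3 is expected to give 20 nM, with a likely range from 5 nM to 80 nM.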

Compound 3, half-maximal inhibitory concentration: 8 nM
Compound 3: the middle estimate sits 2.5-fold (0.40 log units) above what was measured; the measured number falls inside the stated range.
By their numbers in this assay, from the lowest: compounds 3 and 2 (each within the scatter of the next); then compound 1.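

In this assay, putting 4-chlorobenzyl in place of trifluoromethyl on a saturated chain carbon bound to an oxygen next to a carbonyl group gives a 2.0-fold lower number from compound 2 to compound 3 (0.30 log units; within the scatter), so the two compounds cannot be told apart. For the compounds shown here, this is the first single-place comparison in the set, and it shows that this ester position accepts a group of 8 heavy atoms with one six-membered aromatic ring in place of one of 4 heavy atoms with no ring, with inhibition holding at the same level. No measurement on hand explains why the level holds.

As far as these compounds go, whether this acceptance extends to an ester tail ending in an amine or a carboxylic acid remains open. Also open, from the compounds shown here alone, is which of the several differences separates compound 1 from compound 2.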